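The source may report more compounds than this note shows. Statements on the series, on what has been measured and on what is new or still open speak of the compounds shown alone.

Compound 3 `Cc1nc(S(C)(=O)=O)ccc1Oc1ncnc(OC2CCN(C(=O)SC3CC3)CC2)c1F` sits among three compounds that share one core and differ only in the group carried on the amine nitrogen in the ring. In a functional assay on isolated protein for inhibition of Glucose-dependent insulinotropic receptor (Rattus norvegicus), read by HTRF and cAMP accumulation (a higher number here means that more compound is needed for the effect, a lower number that less compound is needed), compound 3 gives 126 nM, the second highest of the three numbers. Compound 2 `Cc1nc(S(C)(=O)=O)ccc1Oc1ncnc(OC2CCN(C(=O)O[C@@H](C)C(F)(F)F)CC2)c1F` gives 109 nM, and the step of a 1.2-fold higher number from compound 2 to compound 3 (0.06 log units; within the scatter) lies within the scatter. Compound 1 `Cc1nc(S(C)(=O)=O)ccc1Oc1ncnc(OC2CCN(C(=O)O[C@H](C)CF)CC2)c1F` gives 1520 nM, and the step of a 12-fold lower number from compound 1 to compound 3 (1.08 log units; beyond the scatter) is large, as is a 14-fold lower number from compound 1 to compound 2 (1.14 log units; beyond the scatter).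

Compound 4 `Cc1nc(S(C)(=O)=O)ccc1Oc1ncnc(OC2CCN(C(=S)OC(C)C)CC2)c1F` is the next step. Its change is a group of 6 heavy atoms (4 carbon, 1 oxygen, 1 sulfur; no ring) in place of a group of 6 heavy atoms (4 carbon, 1 oxygen, 1 sulfur; one three-membered non-aromatic ring of carbon only), on an amine nitrogen in a ring. The two measured steps that bear on it, from compound 1 and from compound 2 to compound 3, both touch this same position and show that a change there can move the number a great deal or hardly at all. No measured pair shows a chain of this kind in place of a ring at this position together with the shift of sulfur and oxygen, so the direction is uncertain. Compound 4 is therefore expected to give a number close to that of compound 3, with room for a moderate rise, estimated at 250 nM within 60 nM to 1000 nM, a step of a 2.0-fold higher number from compound 3 to compound 4 (0.30 log units; within the scatter).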

Compound 4, half-maximal effective concentration: 1050 nM
Compound 4: middle estimate off by 4.2-fold (0.62 log units), on the low side; measured number above the stated range.
By their numbers in this assay, from the lowest: compounds 2 and 3 (each within the scatter of the next); then compounds 4 and 1 (each within the scatter of the next).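

In this assay, the two groups that trade places on the amine nitrogen in the ring have the same count of heavy atoms and the same kinds of atoms, yet the swap gives an 8.3-fold higher number from compound 3 to compound 4 (0.92 log units; beyond the scatter), so these counts alone do not settle the number at this position. The step of a 9.6-fold higher number from compound 2 to compound 4 (0.98 log units; beyond the scatter) is of similar size, while a 1.4-fold lower number from compound 1 to compound 4 (0.16 log units; within the scatter) lies within the scatter, so the four compounds now fall into two pairs, with compounds 2 and 3 in one and compounds 1 and 4 in the other. Nothing measured here accounts for this split.

The change to compound 4 replaces a ring with an open chain and also moves the sulfur from the single-bonded link to the double-bonded one, and the step cannot tell these two changes apart. On these data alone, a group with the three-membered ring on oxygen and a plain carbonyl, or the open isopropyl chain on sulfur, would separate them, and how an amine or a longer chain would fare on this nitrogen remains open.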